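A few compounds are considered here, and "the series" means these few. Any claim that something is new, unique, unknown or untested is made for them only; others in the source may bear on it.

Measured so far:
compound 1 `Cc1ccc(C2=NN(c3nc(-c4ccc(Br)cc4)cs3)C(c3ccc4c(c3)OCCO4)C2)cc1` — 1590 nM
compound 2 `COc1ccc(-c2csc(N3N=C(c4ccc(Cl)cc4)CC3c3ccc4c(c3)OCCO4)n2)cc1` — 3030 nM
compound 3 `Brc1ccc(C2=NN(c3nc(-c4ccc(Br)cc4)cs3)C(c3ccc4c(c3)OCCO4)C2)cc1` — 320 nM

In a functional assay on MCF7 cells (Homo sapiens) for antiproliferative activity, read by MTT assay, with a stated time of 48 h (a lower number here means a stronger inhibitor, a higher number a weaker inhibitor), compound 2 gives the highest of the three numbers. Compound 1 lies nearest, within the scatter of compound 2; compound 3 lies furthest, beyond it. Within the data shown here, the only single-point step among the measured compounds is bromo in place of methyl on an aromatic carbon, a 5.0-fold lower number from compound 1 to compound 3 (0.70 log units; beyond the scatter).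

Compound 4 `COc1ccc(C2=NN(c3nc(-c4ccc(OC)cc4)cs3)C(c3ccc4c(c3)OCCO4)C2)cc1` has not yet been measured in this assay. It differs from compound 2 in one place: methoxy in place of chloro on an aromatic carbon. Among the measured compounds shown here, no measured pair carries methoxy in place of chloro, so the step from compound 1 to compound 3 is the only guide, and it runs the other way: there the number fell when bromo replaced methyl. Taking chloro out of compound 2 and putting methoxy in is read, by that analogy, as a move toward a higher number, but of a size likely near or just beyond the scatter, a 1.7-fold higher number from compound 2 to compound 4 (0.22 log units; within the scatter) being the expected step.

For compound 4 the expected value in this assay is 5000 nM, with a range from 2000 nM to 12000 nM.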

Compound 4, half-maximal inhibitory concentration: 2730 nM
Estimate against measurement, compound 4: 1.8-fold (0.26 log units) above, and the stated range covers the measured number.
By their numbers in this assay, from the lowest: compound 3; then compounds 1, 4 and 2 (each within the scatter of the next).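

In this assay, the change from 4-chlorophenyl to 4-methoxyphenyl gives a 1.1-fold lower number from compound 2 to compound 4 (0.05 log units; within the scatter), so this exchange, which adds a hydrogen-bond acceptor and one heavy atom, leaves compound 2 and compound 4 within the scatter of each other. At the same position, the earlier step, a 5.0-fold lower number from compound 1 to compound 3 (0.70 log units; beyond the scatter), lies beyond the scatter, so the position does respond to some exchanges, although that step was read with a different group elsewhere on the core. Nothing available explains why one exchange gives a step beyond the scatter and the other does not.

Still open, going by these compounds, is how an amine, a carboxylic acid or a longer alkoxy chain would read at this position. Also open, on these data alone, is whether the chloro-to-methoxy step keeps its size in the core of compound 3.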